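The compounds below may be only part of what the source reports. "The series", "measured", "known", "first", "only" and "open" are said of these compounds alone.

Measured so far in an ADME assay on Vero 76 cells (Chlorocebus sabaeus) for cytotoxicity, read by MTT assay, with a stated time of 96 h; on this read-out lower numbers stand for higher toxicity in this test and higher numbers for lower toxicity in this test:
compound 1, `FC(F)(F)c1ccc(-c2nn(-c3ccccc3)cc2CNc2ccc(Br)cc2)cc1`, 17000 nM
compound 2, `Cc1ccc(-c2nn(-c3ccccc3)cc2CNc2ccc(C(F)(F)F)cc2)cc1`, 45000 nM
compound 3, `FC(F)(F)c1ccc(NCc2cn(-c3ccccc3)nc2-c2ccc(C(F)(F)F)cc2)cc1`, 26000 nM

Compound 3 stands second highest of the three numbers; the step of a 1.5-fold higher number from compound 1 to compound 3 (0.18 log units; within the scatter) and the step of a 1.7-fold lower number from compound 2 to compound 3 (0.24 log units; within the scatter) are both within the scatter, so the three measured compounds are not separated by this assay.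

The next compound, compound 4, `Cc1ccc(NCc2cn(-c3ccccc3)nc2-c2ccc(C(F)(F)F)cc2)cc1`, is not yet measured. It differs from compound 3 as follows: methyl in place of trifluoromethyl on an aromatic carbon. The change sits on the aryl ring attached to the amino group, the position that carries bromo in compound 1.

Among the compounds with values here, two measured steps bear on this. The step of a 1.7-fold lower number from compound 2 to compound 3 (0.24 log units; within the scatter) is the same kind of exchange in the opposite direction, at a different aromatic carbon, and stayed within the scatter. The step of a 1.5-fold higher number from compound 1 to compound 3 (0.18 log units; within the scatter) changes the same position as the present step, also within the scatter. Neither gives grounds to expect a shift beyond the scatter in this assay; if anything, a slightly higher number is expected for compound 4, as the reverse of a 1.7-fold lower number from compound 2 to compound 3 (0.24 log units; within the scatter).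

Compound 4 is therefore estimated at 38000 nM, within 18000 nM to 80000 nM, which corresponds to an expected step of a 1.5-fold higher number from compound 3 to compound 4 (0.16 log units; within the scatter).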

Compound 4, half-maximal cytotoxic concentration: 82000 nM
Beside the measured number, compound 4's estimate is 2.2-fold (0.33 log units) below it, and the stated range ends below it.
By their numbers in this assay, from the lowest: compounds 1, 3, 2 and 4 (each within the scatter of the next, the first and the last beyond it).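

In this assay, within the data shown here, the change from (4-(trifluoromethyl)phenyl)amino to (4-methylphenyl)amino gives a 3.2-fold higher number from compound 3 to compound 4 (0.50 log units; beyond the scatter) and is the first single exchange at this position to lie beyond the scatter. Methyl in place of bromo on the same carbon gives a 4.8-fold higher number from compound 1 to compound 4 (0.68 log units; beyond the scatter) whereas trifluoromethyl in place of bromo there gave only a 1.5-fold higher number from compound 1 to compound 3 (0.18 log units; within the scatter) so at this carbon methyl stands apart from both groups, which are themselves not separated. The reverse kind of exchange on the other aryl ring gave a 1.7-fold lower number from compound 2 to compound 3 (0.24 log units; within the scatter) and stayed within the scatter, so in this single pair of steps the size of the exchange depends on the ring that carries it; no measurement at hand accounts for this.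

The compounds shown leave open whether the higher number belongs to methyl alone or extends to a longer chain such as ethyl, or to an amine or a carboxylic acid on the same aromatic carbon. They also leave open what the parent ring with only hydrogen at this carbon would give, and so whether methyl raises the number or bromo and trifluoromethyl lower it.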